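The compounds below may be only part of what the source reports. "The series", "measured", "known", "first", "only" and "open" are said of these compounds alone.

Measured in a toxicity assay on HepG2 2.2.15 cells (Homo sapiens) for cytotoxicity, read by CellTiter-Glo; on this read-out higher numbers stand for lower toxicity in this test and lower numbers for higher toxicity in this test:
Compound 1 `C[C@H]1Cn2ncc(N3CC(c4ccccc4)CC3=O)c2CN1CC(=O)Nc1cc(F)c(F)c(F)c1`: > 2000 nM (a limit)
Compound 2 `C[C@H]1Cn2ncc(N3CC(c4ccccc4)CC3=O)c2CN1C(=O)NCc1cc(F)c(F)c(F)c1`: > 2000 nM (a limit)

Compound 2 stands at > 2000 nM, which is a limit and not a number. Compound 3 `C[C@H]1Cn2ncc(N3CC(c4ccccc4)CC3=O)c2CN1C(=O)Nc1cc(F)c(F)c(F)c1` carries 3,4,5-trifluorophenyl in place of 3,4,5-trifluorobenzyl on an amide-type nitrogen. Going by the values given here, no measured step is available for this change, and the series so far shows only (the limit of > 2000 nM in this assay, at which 2 of the 2 values shown sit). No step beyond the scatter is therefore expected in this assay, in either direction. The expected step is a step that the limit leaves unreadable from compound 2 to compound 3. For compound 3 the estimated value is 2500 nM, with an expected range of 1200 nM to 10000 nM.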

Compound 3, half-maximal cytotoxic concentration: 12800 nM
The estimate for compound 3 lay 5.1-fold (0.71 log units) below the measured number; measured number above the stated range.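

No step can be read from compound 2 to compound 3, since compound 2 stands at a limit: the limit of > 2000 nM in this assay, at which 2 of the 3 values shown sit.

The compounds shown leave open the size of the change from 3,4,5-trifluorobenzyl to 3,4,5-trifluorophenyl on the amide-type nitrogen.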